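Efficacy notes on a dihydroxypyrimidine-type agonist series

The source may hold more compounds than are shown below. What is called first, only, known or untested is meant among the compounds shown, and "the series" means these compounds.

Measured so far:
compound 1 `CCCCCCCCc1cc(O)nc(O)n1` 91.2%
compound 2 `CCCCCCCc1cc(O)cc(O)n1` 87.8%
compound 3 `CCCCCCCc1nc(O)cc(O)n1` 103%

In a functional assay on HEK293 cells for agonist activity at G-protein coupled receptor 84 (Homo sapiens), read by calcium flux (a lower number here means a smaller maximal response, a higher number a larger maximal response), compound 3 gives the highest of the three numbers. Compound 1 stands nearest to it, with a number lower by a margin beyond the scatter, and compound 2 furthest, also beyond the scatter. Going by the values given here, no two measured compounds differ in one place, so no single step size is known from the series itself.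

Compound 4 `N#CCCCCc1nc(O)cc(O)n1` differs from compound 3 as follows: cyano in place of propyl on a saturated chain carbon, four bonds along the chain from an aromatic carbon. Among the compounds with values here, with no matching step among the measured compounds, a downward step from compound 3 to compound 4 is expected in this assay, likely beyond the scatter, given that all three measured compounds carry a plain saturated chain. The expected step is a number 33 percentage points lower from compound 3 to compound 4 (beyond the scatter). Compound 4 is thus estimated at 70%, in the range 40% to 100%.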

Compound 4, largest response reached (reported as percent of maximum), in percent of the reference or control that the assay uses: 55.2%
Beside the measured number, compound 4's estimate is 14.8 percentage points above it; the range from low to high includes it.
By their numbers in this assay, from the lowest: compound 4; then compounds 2 and 1 (each within the scatter of the next); then compound 3.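

Going by these compounds alone, replacing propyl with cyano on a saturated chain carbon, four bonds along the chain from an aromatic carbon, gives the first readable step: in this assay it is a number 47.8 percentage points lower from compound 3 to compound 4 (beyond the scatter), a large loss of maximal response. The chain end is therefore not interchangeable at this position, which the plain saturated chains alone could not show. No measurement shown accounts for this loss.

On these data alone, whether a carboxylic acid or an amine at the same chain end would lower the response as far remains open. So does whether a longer chain ending in cyano would recover it.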